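From 3-chlorophenyl to 4-(trifluoromethyl)phenyl

The source may hold more compounds than are shown below. What is called first, only, known or untested is meant among the compounds shown, and "the series" means these compounds.

Compound 1 `Cc1ccc2[nH]c(-c3ccc(-c4ccc(-c5cccc(Cl)c5)cc4)cc3)nc2c1`: 2510 nM
Compound 2 `COc1ccc(-c2ccc(-c3ccc(-c4nc5ccccc5[nH]4)cc3)cc2)cc1`: 100000 nM

Going by the values given here, in a functional assay on DWD cells (Homo sapiens) for inhibition, read by sulforhodamine B assay (on this read-out lower numbers stand for stronger inhibition of growth and higher numbers for weaker inhibition of growth), compound 1 gives 2510 nM, the lower of the two numbers so far. Compound 2 stands at 100000 nM, higher by more than the usual scatter.

The next compound to be tested is compound 3 `Cc1ccc2[nH]c(-c3ccc(-c4ccc(-c5ccc(C(F)(F)F)cc5)cc4)cc3)nc2c1`. It keeps the core of compound 1 and has 4-(trifluoromethyl)phenyl in place of 3-chlorophenyl on an aromatic carbon. The swap sits on an aromatic carbon of a six-membered aromatic ring of carbon only, para to a large group.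

Among the compounds with values here, no measured pair differs in one place only, so no direct step can guide the expectation. Compound 2 differs from compound 1 in more than one place, which makes its number a weak guide to this swap. The anchor is therefore compound 1 at 2510 nM. In this assay the expected step of a 1.2-fold higher number from compound 1 to compound 3 (0.08 log units; within the scatter) is none beyond the scatter, in either direction. Compound 3 is estimated at 3000 nM with an expected range from 800 nM to 15000 nM on this reading.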

Compound 3, concentration for 50% growth inhibition: 38200 nM
Compound 3: the middle estimate sits 13-fold (1.10 log units) below what was measured; the whole stated range lies below it.
By their numbers in this assay, from the lowest: compound 1; then compound 3; then compound 2.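

In this assay, going by these compounds alone, putting 4-(trifluoromethyl)phenyl in place of 3-chlorophenyl gives a 15-fold higher number from compound 1 to compound 3 (1.18 log units; beyond the scatter), which is the first reading of a change in one place and shows that the number responds strongly to what stands at this position. The entering and leaving groups have much in common: each is one six-membered aromatic ring of carbon only, with 0 hydrogen-bond donors, 0 hydrogen-bond acceptors and no net charge, so this large step comes without any change in those counts, while the entering group has more heavy atoms than the leaving group. Nothing measured here accounts for the size of the step.

The two group names differ both in the substituent on the ring and in the number of its place, so this single step leaves open whether the loss follows the trifluoromethyl group, the loss of chlorine or the change of place. On these data alone, how 4-chlorophenyl or 3-(trifluoromethyl)phenyl would read on the core of compound 1 would separate these, and the response to a phenyl ring carrying an amine or a carboxylic acid also remains open.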